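A few compounds are considered here, and "the series" means these few. Any claim that something is new, unique, unknown or untested is made for them only; others in the source may bear on it.

Measured so far in an assay on cells for inhibition of protein deacetylase HDAC6 (Homo sapiens), read by fluorescence, with stated times of 15 min and 60 min; a lower number here means a stronger inhibitor, a higher number a weaker inhibitor:

Compound 1, `O=C(NO)c1ccc(Cn2nc(-c3ccc(F)cc3)cc2Cc2ccccc2)cc1`, gives 326 nM.
Compound 2, `CCCc1cc(-c2ccc(F)cc2)nn1Cc1ccc(C(=O)NO)cc1`, gives 107 nM.
Compound 3, `O=C(NO)c1ccc(Cn2nc(Cc3ccccc3)cc2-c2ccc(F)cc2)cc1`, gives 420 nM.

Compounds 1 and 3 are built from the same atoms joined differently; the difference between the two cores is not broken down here. The two values sit within the scatter of each other, so no order between compound 1 and compound 3 is claimed. Compound 2 sits lower than both, and against compound 3 the gap is beyond the scatter.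

Going by the values given here, the one change with a measured step is ethyl in place of phenyl on a saturated chain carbon bound to an aromatic carbon. It gives a 3.0-fold lower number from compound 1 to compound 2 (0.48 log units; beyond the scatter), a modest step on the core of compound 1.

Compound 4, `CCCc1cc(-c2ccc(F)cc2)n(Cc2ccc(C(=O)NO)cc2)n1`, is not yet measured. It differs from compound 3 by ethyl in place of phenyl on a saturated chain carbon bound to an aromatic carbon. The place is worded the same as for the step from compound 1 to compound 2, so this is the same change, carried out on the core of compound 3. Among the compounds with values here, the only guide is that single measured step, and with two cores that are within the scatter of each other at the starting point, the same size of step is the plain expectation for compound 4. Carrying over the step from compound 1 to compound 2, the expected step is a 2.8-fold lower number from compound 3 to compound 4 (0.45 log units; beyond the scatter) in this assay. Given that compound 3 gives 420 nM, the estimate for compound 4 is 150 nM, with a range from 70 nM to 350 nM to allow for the step not transferring in full.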

Compound 4, half-maximal inhibitory concentration: 167 nM
Estimate against measurement, compound 4: 1.1-fold (0.05 log units) below, within the range that was stated.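

In this assay, ethyl in place of phenyl on a saturated chain carbon bound to an aromatic carbon, which reads as propyl in place of benzyl when cut one bond further out, gives a 2.5-fold lower number from compound 3 to compound 4 (0.40 log units; beyond the scatter), a modest step. Going by these compounds alone, the change therefore keeps its direction and size on the second core, and the two steps do not differ: the same change on two cores in this assay, a 3.0-fold lower number (0.48 log units; beyond the scatter) from compound 1 to compound 2 and a 2.5-fold lower number (0.40 log units; beyond the scatter) from compound 3 to compound 4, 1.2-fold (0.08 log units) apart, within the scatter of two such steps This shows that the change carried over between the cores of compound 1 and compound 3 in this assay, but with only two pairs it does not show that the step would hold on any other core, and the numbers alone do not explain why the lower value comes with propyl.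

As far as these compounds go, only benzyl and propyl appear at this place, so it remains open how the number responds to a longer chain such as hexyl, a branched chain such as isopropyl, or a chain ending in an amine or a carboxylic acid. The fluorophenyl group and the hydroxamic acid are also the same in all four compounds, leaving open whether the step would persist with a chlorophenyl or pyridyl group in place of the fluorophenyl, or with a carboxylic acid in place of the hydroxamic acid.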